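Replacing the 4-propylphenyl arm: compound 3 to compound 4

The source may hold more compounds than are shown below. What is called first, only, known or untested is meant among the compounds shown, and "the series" means these compounds.

Three members of the series have been run in an assay on isolated protein for inhibition of Rho-associated protein kinase 1 (Homo sapiens), read by scintillation counting, radiometric assay and 33P incorporation, with a stated time of 40 min, in the presence of a further agent that is not named here; on this read-out lower numbers stand for stronger inhibition and higher numbers for weaker inhibition. Compound 1 `CN(C)c1ccc(C(=O)Nc2cccc(NC(=O)COc3ccc4c(c3)OCCO4)c2)cc1` returns only a limit, > 10000 nM. Compound 2 `Cc1coc2cc(OCC(=O)Nc3cccc(NC(=O)c4ccc(N(C)C)cc4)c3)ccc2c1=O` likewise returns only a limit, > 10000 nM. For the measured compounds named here, compound 3 `CCCc1ccc(C(=O)Nc2cccc(NC(=O)COc3ccc4c(=O)ccoc4c3)c2)cc1` gives 143 nM, the sole number among the three; the other two results sit at the limit of > 10000 nM in this assay, at which 2 of the 3 values shown sit, and so allow no ranking against compound 3. Going by the values given here, no two measured compounds differ in a single place, so no measured step exists within the set.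

Compound 4 `CC(C)(C)c1cc(C(=O)Nc2cccc(NC(=O)COc3ccc4c(=O)ccoc4c3)c2)no1` is the next to be tested in this assay. It differs from compound 3 in one place: 5-(tert-butyl)-1,2-oxazol-3-yl in place of 4-propylphenyl on a carbonyl carbon. The carbonyl and the amide-type nitrogen are kept; the one six-membered aromatic ring of carbon only gives way to the 5-(tert-butyl)-1,2-oxazol-3-yl group, a five-membered aromatic ring with 2 hetero atoms.

Nothing yet measured shows how this position tolerates change. The expectation is therefore a step of a 1.4-fold higher number from compound 3 to compound 4 (0.15 log units; within the scatter), within or close to the usual scatter and in no settled direction. Compound 4 is expected to give about 200 nM in this assay, with a range from 50 nM to 800 nM.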

Compound 4, half-maximal inhibitory concentration: 101 nM
Estimate against measurement, compound 4: 2.0-fold (0.30 log units) above; the measured number falls inside the stated range.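

In this assay, for the compounds shown here, the first measured change at this position gives a 1.4-fold lower number from compound 3 to compound 4 (0.15 log units; within the scatter), so 5-(tert-butyl)-1,2-oxazol-3-yl and 4-propylphenyl on a carbonyl carbon cannot be told apart in this read-out. One six-membered aromatic ring of carbon only gives way to one five-membered aromatic ring with 2 hetero atoms, and 2 hydrogen-bond acceptors enter where none leave, yet the two values lie within the scatter of each other, so this position accepts both groups. Compounds 1 and 2 could not show this, since neither forms a single-place pair with another measured compound and each returns only a limit: the limit of > 10000 nM in this assay, at which 2 of the 4 values shown sit.

From the compounds shown here alone, whether this tolerance extends to groups of another kind on the carbonyl carbon stays open, and a small methyl group, a ring carrying an amine or a ring carrying a carboxylic acid would test it. Also open, going by these compounds, is how far the ring and the tert-butyl group each count, which a phenyl ring bearing tert-butyl or the 1,2-oxazol-3-yl ring without tert-butyl would help to separate.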